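The compounds below may be only part of what the source reports. "The series", "measured", "known", "first", "only" and "open" are said of these compounds alone.

Of the compounds shown here, three of one shared core have been tested in a functional assay on MCF7 cells (Homo sapiens) for antiproliferative activity, read by MTT assay, with a stated time of 48 h, tested at 50 uM; on this read-out lower numbers stand for a stronger effect and higher numbers for a weaker effect at the one concentration tested. Compound 1 `OC(CCn1nc2c(Br)c(Br)c(Br)c(Br)c2n1)c1ccc(F)cc1` gives 7% in this assay. Compound 2 `OC(CCn1nc2c(Br)c(Br)c(Br)c(Br)c2n1)c1cccc(Cl)c1` gives 12% in this assay, which is the second highest of the three numbers; its nearest neighbour is compound 1, and its furthest is compound 3 `C[C@H](O)CCn1nc2c(Br)c(Br)c(Br)c(Br)c2n1`, which gives 87% in this assay, a gap that lies beyond the scatter. Going by the values given here, the move from compound 1 to compound 2, a number 5 percentage points higher from compound 1 to compound 2 (within the scatter), is the only measured step that swaps one aryl group for another on the saturated chain carbon bound to an oxygen.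

Compound 4 `OC(CCn1nc2c(Br)c(Br)c(Br)c(Br)c2n1)c1ccc(Cl)cc1` has not yet been measured. It differs from compound 2 by 4-chlorophenyl in place of 3-chlorophenyl on a saturated chain carbon bound to an oxygen on a saturated carbon and a saturated chain carbon. Among the compounds with values here, the one measured step of the same kind stayed within the scatter, so compound 4 is expected to sit close to compound 2 in this assay, and the expected step of a number 2 percentage points lower from compound 2 to compound 4 (within the scatter) is not expected to exceed the scatter. Compound 4 is therefore estimated at 10%, between 2% and 28%, in this assay.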

Compound 4, a percentage reported as activity, at one concentration (the size of the read-out at that concentration, not a potency): 9%
Estimate against measurement, compound 4: 1 percentage points above; the measured number falls inside the stated range.
By their numbers in this assay, from the lowest: compounds 1, 4 and 2 (each within the scatter of the next); then compound 3.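

In this assay, 4-chlorophenyl in place of 3-chlorophenyl on the saturated chain carbon bound to an oxygen gives a number 3 percentage points lower from compound 2 to compound 4 (within the scatter), so moving the chlorine on the aryl ring makes no difference that this read-out can separate. Chloro in place of fluoro on an aromatic carbon gives a number 2 percentage points higher from compound 1 to compound 4 (within the scatter), which shows the halogen alone being exchanged with no separable change, whereas the earlier step altered the halogen and its ring place together. Nothing measured here offers a reason for either result.

The compounds shown carry only a single chlorine or fluorine on the phenyl ring, so it stays open whether an unsubstituted phenyl, or a methoxy group or an amine on that ring, would give a similar number in this assay. Going by these compounds, a longer chain in place of the present saturated chain remains open as well.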